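Compound 3: one added hydroxy on a limit-bound series

The compounds below may be only part of what the source reports. "The series", "measured", "known", "first", "only" and "open" are said of these compounds alone.

In an ADME assay on BJ cells (Homo sapiens) for cytotoxicity, with a stated time of 72 h (a lower number here means that less compound is needed, a higher number that more compound is needed for the effect), compound 1 `Nc1nc(-c2ccccn2)nn1-c1ncnc2ccccc12` gives > 50000 nM, a limit and not a number. Compound 2 `COc1ccc2ncnc(-n3nc(-c4ccccn4)nc3N)c2c1` gives > 27000 nM, also a limit and not a number. Going by the values given here, the one measured step, a step that the two limits leave unreadable from compound 1 to compound 2, is a methoxy in place of hydrogen and gives no size to build on. Compound 3 `COc1cc2c(-n3nc(-c4ccccn4)nc3N)ncnc2cc1O` adds to the core of compound 2: hydroxy in place of hydrogen on an aromatic carbon, ortho to a methoxy group. The expected step is a step that the limit leaves unreadable from compound 2 to compound 3, with none expected beyond the scatter. For compound 3 the estimate in this assay is 30000 nM, expected within 12000 nM to 60000 nM.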

Compound 3, half-maximal effective concentration: > 27000 nM
Compound 3: a limit, no number; the forecaster's own chance of this, stated with the estimate: 75%; the middle value is on the limit's open side.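

Compound 2 and compound 3 both end in a limit and not a number, so no size can be read for the step between them: the limit of > 27000 nM in this assay, at which 2 of the 3 values shown sit. The compounds shown leave open the actual half-maximal effective concentration of each, and whether the added hydroxy shifts it.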